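From 4-methylphenyl to 2-chlorophenyl on a sulfur

A few compounds are considered here, and "the series" means these few. Any claim that something is new, unique, unknown or untested is made for them only; others in the source may bear on it.

Measured in a functional assay on A549 cells (Homo sapiens) for antiproliferative activity, read by MTT assay, with a stated time of 72 h; on this read-out lower numbers stand for stronger inhibition and higher numbers for weaker inhibition:
- Compound 1 `Cc1ccc(SC(=S)N2CCN(C(=O)OC(C)(C)C)CC2)cc1` gives 2110 nM
- Compound 2 `CC(C)(C)OC(=O)N1CCN(C(=S)Sc2ccc(Cl)cc2)CC1` gives 1070 nM
- Compound 3 `Cc1ccccc1SC(=S)N1CCN(C(=O)OC(C)(C)C)CC1` gives 2270 nM

Compound 1 lies within the scatter of both compound 2 and compound 3, while those two are separated by a modest gap (a 2.1-fold higher number from compound 2 to compound 3 (0.33 log units; beyond the scatter)). Compound 4 `CC(C)(C)OC(=O)N1CCN(C(=S)Sc2ccccc2Cl)CC1` has not been measured. It carries 2-chlorophenyl in place of 4-methylphenyl on a sulfur. Among the compounds with values here, no measured compound carries this group, so two steps from compound 1 bear on the change. One covers chloro in place of methyl (a 2.0-fold lower number from compound 1 to compound 2 (0.29 log units; within the scatter)) and the other covers 2-methylphenyl in place of 4-methylphenyl (a 1.1-fold higher number from compound 1 to compound 3 (0.03 log units; within the scatter)). Both lie within the scatter, so a slightly lower number is expected in this assay, with no step beyond the scatter. The estimated step is small (a 1.5-fold lower number from compound 1 to compound 4 (0.18 log units; within the scatter)). Compound 4 is estimated at 1400 nM (expected range 700 nM to 2800 nM).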

Compound 4, half-maximal inhibitory concentration: 1560 nM
Compound 4: middle estimate off by 1.1-fold (0.05 log units), on the low side; measured number inside the range.
By their numbers in this assay, from the lowest: compounds 2, 4, 1 and 3 (each within the scatter of the next, the first and the last beyond it).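

Compound 4 gives the series a second pair for chloro in place of methyl, and it shows that 2-chlorophenyl and 4-chlorophenyl on the sulfur cannot be told apart in this assay (a 1.5-fold higher number from compound 2 to compound 4 (0.16 log units; within the scatter)). The other two comparisons also stay inside the scatter, both the full exchange of 4-methylphenyl for 2-chlorophenyl (a 1.4-fold lower number from compound 1 to compound 4 (0.13 log units; within the scatter)) and chloro in place of methyl on the 2-methylphenyl compound (a 1.5-fold lower number from compound 3 to compound 4 (0.16 log units; within the scatter)). Chloro in place of methyl now gives a step in the same direction on two cores, although neither step alone lies beyond the scatter: the same change on two cores in this assay, a 2.0-fold lower number (0.29 log units; within the scatter) from compound 1 to compound 2 and a 1.5-fold lower number (0.16 log units; within the scatter) from compound 3 to compound 4, 1.4-fold (0.13 log units) apart, within the scatter of two such steps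

The compounds shown leave open what happens with anything other than methyl or chloro on the phenyl ring. A methoxy group, a trifluoromethyl group or a dimethylamino group on that ring, or a benzyl group on the sulfur, would show whether the numbers leave the range of these four compounds.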